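A few compounds are considered here, and "the series" means these few. Any claim that something is new, unique, unknown or untested is made for them only; others in the source may bear on it.

Compound 1 `O=S(=O)(/C=C/c1ccccc1)Cc1ccc(Nc2ncnc3ccccc23)cc1` stands in a functional assay on NCI/ADR-RES cells (Homo sapiens) for inhibition (on this read-out lower numbers stand for stronger inhibition of growth and higher numbers for weaker inhibition of growth), at > 100000 nM, which is a limit and not a number. Compound 2 `O=S(=O)(/C=C/c1ccc(Br)cc1)Cc1ccc(Nc2ncnc3ccccc23)cc1` gives > 100000 nM in this assay, again a limit. All the evidence so far is the limit of > 100000 nM in this assay, at which 2 of the 2 values shown sit.

Compound 3 `O=S(=O)(/C=C/c1ccc(Cl)cc1)Cc1ccc(Nc2ncnc3ccccc23)cc1` differs from compound 1 by chloro in place of hydrogen on an aromatic carbon, turning phenyl into 4-chlorophenyl. For the measured compounds named here, the one measured step that bears on this is a step that the two limits leave unreadable from compound 1 to compound 2, bromo in place of hydrogen on an aromatic carbon. It offers no size to carry over, but it gives no sign of a move towards stronger inhibition either. No step beyond the scatter is therefore expected in this assay, in either direction. The expected step is a number no higher from compound 1 to compound 3 (the limit leaves the size open). Compound 3 is estimated at 100000 nM, with an expected range from 50000 nM to 200000 nM, and will most likely be reported as a limit again.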

Compound 3, concentration for 50% growth inhibition: > 100000 nM
Compound 3 gave a limit, no number; the forecaster's own chance of this, stated with the estimate: 90%; the middle value sits exactly at the limit.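

For the compounds shown here, compound 1, compound 2 and compound 3 all give only a limit, so no step among them can be read: the limit of > 100000 nM in this assay, at which 3 of the 3 values shown sit. The compounds shown leave open how large the bromo and chloro steps are in this assay, and whether any change to this series yields a number rather than a limit.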